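This account rests on a few compounds, and the source may have more. Where it says the series, first, only, none or still open, it means among the compounds named here.

Measured so far in an ADME assay on L02 cells (Homo sapiens) for inhibition, read by MTT assay, with a stated time of 72 h; a lower number here means a stronger inhibitor, a higher number a weaker inhibitor:

Compound 1 `CC/C=C/C(=O)Nc1cccc(Oc2nc(Nc3cccc(OC)c3)nc3ccsc23)c1` gives > 50000 nM, which is a limit of the assay rather than a number.
Compound 2 `CCC/C=C/C(=O)Nc1cccc(Oc2nc(Nc3cccc(OC)c3)nc3ccsc23)c1` gives > 50000 nM, again a limit.
Compound 3 `CC/C=C/C(=O)Nc1cccc(Oc2nc(Nc3cccc(C#N)c3)nc3ccsc23)c1` gives > 50000 nM, also a limit.

Compound 2 differs from compound 1 in one place: methyl in place of hydrogen on a saturated chain carbon, two bonds along the chain from a double-bonded chain carbon. The step that the two limits leave unreadable from compound 1 to compound 2 cannot be read because the limit of > 50000 nM in this assay, at which 3 of the 3 values shown sit, leaves both ends of it open. Compound 3 differs from compound 1 in the core: cyano in place of methoxy on an aromatic carbon. The step that the two limits leave unreadable from compound 1 to compound 3 is unreadable for the same reason, because the limit of > 50000 nM in this assay, at which 3 of the 3 values shown sit, applies to both compounds.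

Compound 4 `CC(C)/C=C/C(=O)Nc1cccc(Oc2nc(Nc3cccc(C#N)c3)nc3ccsc23)c1` has not yet been measured in this assay. It differs from compound 3 by methyl in place of hydrogen on a saturated chain carbon bound to a double-bonded chain carbon and a saturated chain carbon. This is the same kind of change as that from compound 1 to compound 2, but not the same: there the methyl entered on a saturated chain carbon, two bonds along the chain from a double-bonded chain carbon, whereas here it enters on a saturated chain carbon bound to a double-bonded chain carbon and a saturated chain carbon.

The step from compound 3 to compound 4 is expected to be a step that the limit leaves unreadable from compound 3 to compound 4, a guess that rests only on (the limit of > 50000 nM in this assay, at which 3 of the 3 values shown sit), since every measured compound, including compound 3, sits at that limit and no readable step exists among them. Compound 4 is therefore expected to give about 80000 nM in this assay, most likely between 35000 nM and 250000 nM, and most likely reported as a limit again.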

Compound 4, half-maximal inhibitory concentration: > 50000 nM
Compound 4 ended at the assay's limit; the forecaster's own chance of this, stated with the estimate: 85%; the middle value is on the limit's open side.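

In this assay compound 4 gives > 50000 nM, which is a limit of the assay and not a number. As far as these compounds go, the step from compound 3 to compound 4 therefore cannot be read, because both of its ends stay open: the limit of > 50000 nM in this assay, at which 4 of the 4 values shown sit.

The compounds shown leave open how far past this limit each one lies, and whether the chain changes or cyano in place of methoxy alter the read-out at all.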